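A few compounds are considered here, and "the series" means these few. Any claim that something is new, unique, unknown or untested is made for them only; others in the source may bear on it.

The measured compounds:
compound 1, `Cc1ccc(COc2ccc(-c3cc(CN4CCN(Cc5ccc(C(F)(F)F)cc5)CC4)no3)cc2)cc1`, 1500 nM
compound 2, `FC(F)(F)c1ccc(CN2CCN(Cc3cc(-c4ccc(OCc5ccccc5Cl)cc4)on3)CC2)cc1`, 1000 nM
compound 3, `FC(F)(F)c1ccc(CN2CCN(Cc3cc(-c4ccc(OCc5ccc(Cl)cc5)cc4)on3)CC2)cc1`, 4000 nM

In a functional assay on Huh-7 cells (Homo sapiens) for antiproliferative activity, read by sulforhodamine B assay, with a stated time of 72 h (a higher number here means a weaker inhibitor, a lower number a stronger inhibitor), compound 1 stands second highest of the three numbers; compound 2 is nearest to it, compound 3 furthest. Compound 4 `N#Cc1ccccc1COc1ccc(-c2cc(CN3CCN(Cc4ccc(C(F)(F)F)cc4)CC3)no2)cc1` differs from compound 1 by 2-cyanophenyl in place of 4-methylphenyl on a saturated chain carbon bound to an oxygen on an aromatic ring. The step that bears on this most closely is a 1.5-fold lower number from compound 1 to compound 2 (0.18 log units; within the scatter), where a 2-chlorophenyl entered on the same carbon. The steps of a 2.7-fold higher number from compound 1 to compound 3 (0.43 log units; beyond the scatter) and a 4.0-fold higher number from compound 2 to compound 3 (0.60 log units; beyond the scatter) show that the 4-chlorophenyl gave a modestly higher number than either the 4-methylphenyl or the 2-chlorophenyl. A step of a 1.3-fold lower number from compound 1 to compound 4 (0.10 log units; within the scatter) is therefore expected, not beyond the scatter. The estimate for compound 4 is 1200 nM, within 500 nM to 3000 nM.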

Compound 4, half-maximal inhibitory concentration: 5000 nM
The estimate for compound 4 lay 4.2-fold (0.62 log units) below the measured number, outside the stated range (above it).
By their numbers in this assay, from the lowest: compounds 2 and 1 (each within the scatter of the next); then compounds 3 and 4 (each within the scatter of the next).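

In this assay this carbon proved sensitive to the group on the 2-substituted phenyl: cyano in place of chloro gave a 5.0-fold higher number from compound 2 to compound 4 (0.70 log units; beyond the scatter) and showed that 2-chlorophenyl and 2-cyanophenyl are not interchangeable here. Against the 4-methylphenyl, the 2-cyanophenyl gave a 3.3-fold higher number from compound 1 to compound 4 (0.52 log units; beyond the scatter) while a 1.3-fold higher number from compound 3 to compound 4 (0.10 log units; within the scatter) placed it with the 4-chlorophenyl, not with the 2-chlorophenyl. Nothing available explains this difference. Going by these compounds, whether a plain phenyl, a 2-methoxyphenyl or a 2-aminophenyl on this carbon would fall with compound 2 or with compound 4 stays open.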